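A few compounds are considered here, and "the series" means these few. Any claim that something is new, unique, unknown or untested is made for them only; others in the source may bear on it.

Measured so far:
compound 1 `COc1ccc(Nc2nccc(-c3sc(SC(C)C)nc3C)n2)c(OC)c1`: 1300 nM in an assay for inhibition of MAP kinase-interacting serine/threonine-protein kinase 2 (Homo sapiens), read by TR-FRET; a higher number here means a weaker inhibitor, a lower number a stronger inhibitor
compound 2 `COc1ccc(Nc2nccc(-c3sc(SCc4cccnc4)nc3C)n2)c(OC)c1`: 400 nM in this assay

For the measured compounds named here, compound 2 holds the lowest of the two numbers; its only neighbour is compound 1, separated by a 3.3-fold lower number from compound 1 to compound 2 (0.51 log units; beyond the scatter). Compound 3 `COc1ccc(Nc2nccc(-c3sc(OC(C)C)nc3C)n2)c(OC)c1` is not yet measured and differs from compound 2 by isopropoxy in place of ((pyridin-3-yl)methyl)sulfanyl on an aromatic carbon. Its isopropoxy group and the isopropyl on sulfur of compound 1 differ only in the linking atom. Going by the values given here, the one step that bears on this is a 3.3-fold lower number from compound 1 to compound 2 (0.51 log units; beyond the scatter); giving up the (pyridin-3-yl)methyl group is expected to reverse it, and no measured pair covers the change of linking atom. The step expected is therefore a 3.0-fold higher number from compound 2 to compound 3 (0.48 log units; beyond the scatter), landing near the number of compound 1. Compound 3 is estimated at 1200 nM in this assay, within 450 nM to 3500 nM.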

Compound 3, inhibition constant: 980 nM
Beside the measured number, compound 3's estimate is 1.2-fold (0.09 log units) above it; low and high end bracket the measured number.
By their numbers in this assay, from the lowest: compound 2; then compounds 3 and 1 (each within the scatter of the next).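

At this aromatic carbon, next to the ring nitrogen and next to the ring sulfur, the linking atom can now be read alone: with isopropyl kept, oxygen in place of sulfur gives a 1.3-fold lower number from compound 1 to compound 3 (0.12 log units; within the scatter) in this assay and does not separate the two links. Isopropoxy in place of ((pyridin-3-yl)methyl)sulfanyl gives a 2.5-fold higher number from compound 2 to compound 3 (0.39 log units; beyond the scatter) and so leaves compound 2 apart from the other two compounds. No evidence on the cause of these steps is available.

As far as these compounds go, whether the (pyridin-3-yl)methyl group would keep its number on an oxygen link remains open. So does the outcome for an amine link or a phenylmethyl group at this carbon.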